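Cytotoxicity Notes: Amide, Ketone and Fluorobenzyl Amide Analogues

This account rests on a few compounds, and the source may have more. Where it says the series, first, only, none or still open, it means among the compounds named here.

Measured so far:
Compound 1 `CN(Cc1ccccc1)C(=O)c1nc(Cc2ccccc2C(F)(F)F)n(C)c(=O)c1O`; in an ADME assay on HepG2 cells (Homo sapiens) for cytotoxicity, in the presence of a further agent that is not named here (on this read-out higher numbers stand for weaker inhibition and lower numbers for stronger inhibition), compound 1 gives > 100000 nM, which is a limit of the assay and not a number.
Compound 2 `Cn1c(Cc2ccccc2C(F)(F)F)nc(C(=O)CCc2ccccc2)c(O)c1=O`; in this assay compound 2 gives > 100000 nM, again a limit of the assay.
Compound 3 `CC(c1ccccc1C(F)(F)F)c1nc(C(=O)NCc2ccccc2)c(O)c(=O)n1C`; in this assay compound 3 gives > 100000 nM, also a limit.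

Compound 2 stands at the limit of this assay, and so does every other measurement in the set: the limit of > 100000 nM in this assay, at which 3 of the 3 values shown sit. Among the compounds with values here, the only single-point step available, a step that the two limits leave unreadable from compound 1 to compound 2, therefore has no readable size, since both of its ends are limits. Compound 1 and compound 3 likewise show two limits and nothing more.

Compound 4 `Cn1c(Cc2ccccc2C(F)(F)F)nc(C(=O)NCc2ccc(F)cc2)c(O)c1=O` is reached from compound 2 by one change, ((4-fluorobenzyl)amino in place of phenethyl on a carbonyl carbon), on the carbonyl carbon whose other neighbour is an aromatic carbon. Within the data shown here, no measured step bears on this change with a readable magnitude. On the numbers shown, the step that the limit leaves unreadable from compound 2 to compound 4 is expected to be none beyond the scatter, with compound 4 most likely returning only a limit again. Compound 4 is estimated at 150000 nM in this assay. The expected range for compound 4 runs from 50000 nM to 500000 nM.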

Compound 4, half-maximal inhibitory concentration: > 100000 nM
Compound 4: only a limit was reported; the forecaster's own chance of this, stated with the estimate: 85%; the middle value is on the limit's open side.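

In this assay compound 4 gives > 100000 nM as a limit of the assay and not a number. Within the data shown here, no step from compound 1 or compound 2 to compound 4 can be read, since both ends of each are limits: the limit of > 100000 nM in this assay, at which 4 of the 4 values shown sit.

The compounds shown leave open whether any change on the carbonyl carbon alters this read-out, as none has a value inside the measurable range.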